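This account rests on a few compounds, and the source may have more. Where it says the series, first, only, none or still open, it means among the compounds named here.

In a functional assay on MCF7 cells (Homo sapiens) for inhibition, read by MTT assay, with a stated time of 72 h (a lower number here means a stronger inhibitor, a higher number a weaker inhibitor), three compounds have been measured so far. Compound 1 (`CCN(CC)CC(O)Cn1cc(CC(=O)O)c2ccccc21`) gives 3160 nM, compound 2 (`O=C(O)Cc1cn(CC(O)CN2CCCC2)c2ccccc12`) gives 1150 nM, and compound 3 (`O=C(O)CCc1cn(CC(O)CN2CCCCC2)c2ccccc12`) gives 8790 nM. That last number is the highest of the three, which makes compound 3 the weakest inhibitor of the set. Compound 4 (`O=C(O)CCc1cn(CC(O)CN2CCCC2)c2ccccc12`) differs from compound 3 in one place: pyrrolidin-1-yl in place of piperidin-1-yl on a saturated chain carbon, two bonds along the chain from an oxygen on a saturated carbon. In words, pyrrolidin-1-yl stands in place of piperidin-1-yl on a saturated chain carbon, two bonds along the chain from an oxygen on a saturated carbon.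

Within the data shown here, no measured step starts from piperidin-1-yl. Among the measured compounds shown here, the nearest guide is the one measured step that brings in pyrrolidin-1-yl at this place, a 2.7-fold lower number from compound 1 to compound 2 (0.44 log units; beyond the scatter), where it replaces diethylamino. That step is modest but beyond the scatter. It leaves a different group and belongs to a pair with a different shared core, so it offers only a loose indication. A modest lowering in this assay is therefore expected, and the size estimated is a 2.2-fold lower number from compound 3 to compound 4 (0.34 log units; beyond the scatter). For compound 4 the expected value is 4000 nM, with an estimated range from 1600 nM to 9500 nM.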

Compound 4, half-maximal inhibitory concentration: > 10000 nM
Compound 4: no number, only a limit; the forecaster's own chance of this, stated with the estimate: 2%; at least 2.5-fold (0.39 log units) between middle value and limit.
By their numbers in this assay, from the lowest: compound 2; then compound 1; then compound 3. At a limit, above all of these: compound 4.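

In this assay compound 4 gives no number, only a limit: the limit of > 10000 nM in this assay, at which 1 of the 4 values shown sits. The step from piperidin-1-yl to pyrrolidin-1-yl reads an at least 1.1-fold higher number from compound 3 to compound 4 (0.05 log units; that floor lies within the scatter), so the lowering seen with pyrrolidin-1-yl in a 2.7-fold lower number from compound 1 to compound 2 (0.44 log units; beyond the scatter) does not appear in this pair, although the floor alone fixes no rise and leaves the true size of the step unknown. With pyrrolidin-1-yl held the same, carboxymethyl in place of carboxy on a saturated chain carbon bound to an aromatic carbon gives an at least 8.6-fold higher number from compound 2 to compound 4 (0.93 log units; beyond the scatter), the first single change shown at this other place, and it shows that the chain bearing the acid can weigh heavily on the number in this assay.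

Open, as far as these compounds go, is how a piperidin-1-yl compound with carboxy on that chain carbon would stand against compound 2 and compound 3, which would show whether the two changes act independently of each other. Also open, from the compounds shown here alone, is how a still longer chain ending in a carboxylic acid, or a primary amide in place of that acid, would read in this assay.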